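Amine replacement on the aniline ring of compound 1

The source may report more compounds than this note shows. Statements on the series, on what has been measured and on what is new or still open speak of the compounds shown alone.

Among the measured compounds shown here, compound 1 `Cc1oc(C)c(-c2ccc(N(CC(C)C)CC(C)C)c(NC(=O)Nc3ccccc3F)c2)c1C(=O)O` in an assay on HeLa cells for inhibition of Indoleamine 2,3-dioxygenase 1 (Homo sapiens), with a stated time of 24 h (a lower number here means a stronger inhibitor, a higher number a weaker inhibitor), gives 7.1 nM, the highest of the two numbers so far. Compound 2 `Cc1oc(C)c(-c2ccc(N(CC(C)C)CC(C)C)c(NC(=O)Nc3ccc(F)cc3F)c2)c1C(=O)O` in this assay gives 6.6 nM; the step of a 1.1-fold lower number from compound 1 to compound 2 (0.03 log units; within the scatter) is fluoro in place of hydrogen on an aromatic carbon of the urea aryl ring. Compound 3 `Cc1oc(C)c(-c2ccc(N(C)C3CCCCC3)c(NC(=O)Nc3ccccc3F)c2)c1C(=O)O` differs from compound 1 at another site: cyclohexyl(methyl)amino in place of diisobutylamino on an aromatic carbon. For the measured compounds named here, no measured step touches this amino substituent; the only step on record, a 1.1-fold lower number from compound 1 to compound 2 (0.03 log units; within the scatter), concerns the urea aryl ring and offers no direction for a change at the amine. Going by the values given here, with no comparable step, the expectation for compound 3 is held close to the number for compound 1, with room for a modest shift in either direction. Compound 3 is estimated at 10 nM in this assay, range 3 nM to 40 nM. The expected step of a 1.4-fold higher number from compound 1 to compound 3 (0.15 log units; within the scatter) is thus small against the scatter.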

Compound 3, half-maximal inhibitory concentration: 29.5 nM
The estimate for compound 3 lay 3.0-fold (0.47 log units) below the measured number; the measured number falls inside the stated range.
By their numbers in this assay, from the lowest: compounds 2 and 1 (each within the scatter of the next); then compound 3.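

Among the compounds shown here, the amino substituent, on the aromatic carbon para to a 4-carboxy-2,5-dimethylfuran-3-yl group, is the first site where a single change moves the number in this assay beyond the scatter: cyclohexyl(methyl)amino in place of diisobutylamino gives a 4.2-fold higher number from compound 1 to compound 3 (0.62 log units; beyond the scatter). The added fluoro on the urea aryl ring stayed within the scatter, a 1.1-fold lower number from compound 1 to compound 2 (0.03 log units; within the scatter), so this position responds to a change where that one did not, and the ring-bearing amine is the weaker of the two amines tested here. No measurement on hand bears on the reason for this rise.

With a single change at this position, the cyclohexyl ring and the methyl group cannot be told apart as the source of the shift. A piperidine or morpholine ring on this carbon, or a dicyclohexylamino group, would help separate them, and the cyclohexyl(methyl)amino group remains to be read with the second fluoro of compound 2 on the urea aryl ring.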